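A Phenyl Swap on the Ring Nitrogen of Compound 2

The source may hold more compounds than are shown below. What is called first, only, known or untested is meant among the compounds shown, and "the series" means these compounds.

Of the compounds shown here, three sharing one core have been tested in a functional assay on ECV-304 cells (Homo sapiens), read by MTT assay, with stated times of 24 h and 12 h, tested at 12.5 uM; a lower number here means a weaker effect, a higher number a stronger effect of the compound at the concentration tested. Compound 1 `Cc1nc(C)c(COC(=O)CCCC[C@@H]2CCSS2)nc1C` gives -60%. Compound 2 `Cc1nc(C)c(CSc2nnnn2C)nc1C` gives -220%, the lowest of the three numbers. Compound 3 `Cc1nc(C)c(CSc2nc3ccccc3s2)nc1C` gives 4.33%. Compound 2 therefore stands at the bottom: compound 1 lies higher by an amount beyond the usual scatter, and compound 3 lies higher still, also beyond the scatter. No two of these compounds differ in only one place, so no single step can be read from the measured set.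

Compound 4 `Cc1nc(C)c(CSc2nnnn2-c2ccccc2)nc1C` has not yet been measured. It differs from compound 2 in one place: phenyl in place of methyl on an aromatic nitrogen. Going by the values given here, nothing among the measured compounds shows what such a change does here. The step of a number 100 percentage points higher from compound 2 to compound 4 (beyond the scatter) is expected to be upward, though with large uncertainty. Compound 4 is estimated to give -120% in this assay, within a range from -260% to 20%.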

Compound 4, a percentage reported as activity, at one concentration (the size of the read-out at that concentration, not a potency): -135%
Compound 4: the middle estimate sits 15 percentage points above what was measured; measured number inside the range.
By their numbers in this assay, from the lowest: compound 2; then compound 4; then compound 1; then compound 3.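

In this assay, going by these compounds alone, putting phenyl in place of methyl on this aromatic nitrogen gives a number 85 percentage points higher from compound 2 to compound 4 (beyond the scatter), the first change in this set that can be read from a single place, and it shows that the group on this nitrogen affects the read-out. Even so, compound 4 gives -135%, so this change alone does not bring the number above zero. No accompanying measurement bears on the reason for this step.

The compounds shown leave open whether the aromatic ring itself matters or whether any group with more carbon atoms on this nitrogen would do the same, which a butyl chain or a cyclohexyl ring could help to separate. They also leave open how a phenyl carrying an amine or a carboxylic acid would behave at this position.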